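Ether versus carbamoyl at the saturated ring carbon

The compounds below may be only part of what the source reports. "The series", "measured", "known", "first", "only" and "open" are said of these compounds alone.

Among the measured compounds shown here, compound 2 `Cc1nn(-c2ncnc3nc[nH]c23)c2c1C(C(=O)N(C)c1ccccc1)CC(=O)N2` gives 5220 nM in a functional assay on HEK293 cells for agonist activity at G-protein coupled receptor 39 (Homo sapiens), read by scintillation proximity assay and inositol phosphate accumulation, with a stated time of 75 min (on this read-out lower numbers stand for an effect already at smaller amounts and higher numbers for an effect only at larger amounts of compound), the highest of the two numbers measured so far. Its nearest neighbour, compound 1 `Cc1nn(-c2ncnc3nc[nH]c23)c2c1C(OCc1ccccc1C#N)CC(=O)N2`, gives 127 nM in this assay. For the measured compounds named here, the single step measured so far is a 41-fold higher number from compound 1 to compound 2 (1.61 log units; beyond the scatter), a large loss on exchanging an ether for a carbamoyl on the saturated ring carbon.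

Compound 3 `Cc1nn(-c2ncnc3nc[nH]c23)c2c1C(OCCc1ccccc1)CC(=O)N2` differs from compound 2 by phenethyloxy in place of methyl(phenyl)carbamoyl on a saturated ring carbon. Going by the values given here, this change reverses the same type of exchange and bears directly on that step: compound 3 returns to an ether, as in compound 1, though with phenethyloxy rather than (2-cyanobenzyl)oxy, and no measured pair shows what that difference alone is worth. Because a 41-fold higher number from compound 1 to compound 2 (1.61 log units; beyond the scatter) was large, a large step back toward lower numbers is expected, with uncertainty about how closely compound 1 is matched. Compound 3 is therefore expected to give 400 nM in this assay, with a range from 100 nM to 2000 nM. The expected step is therefore a 13-fold lower number from compound 2 to compound 3 (1.12 log units; beyond the scatter).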

Compound 3, half-maximal effective concentration: 40 nM
Compound 3: middle estimate off by 10-fold (1.00 log units), on the high side, and the stated range ends above it.
By their numbers in this assay, from the lowest: compound 3; then compound 1; then compound 2.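

In this assay the exchange of methyl(phenyl)carbamoyl for phenethyloxy on the saturated ring carbon gives a 130-fold lower number from compound 2 to compound 3 (2.12 log units; beyond the scatter), so the large gap between carbamoyl and ether at this position now holds for two different ethers rather than for (2-cyanobenzyl)oxy alone. The group on the ether oxygen also matters here, though less: benzyl in place of 2-cyanophenyl gives a 3.2-fold lower number from compound 1 to compound 3 (0.50 log units; beyond the scatter), a modest step next to the carbamoyl gap. No measurement at hand accounts for either step.

The step between the two ethers joins a change in chain length with the loss of the nitrile, and a plain benzyloxy group at this carbon would be needed to separate the two. Also open, as far as these compounds go, is how an amine at this carbon, or an ether with a longer chain than phenethyloxy, would compare with these ethers.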